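Aryl swap on the ring nitrogen: compound 3 to compound 4

A few compounds are considered here, and "the series" means these few. Any claim that something is new, unique, unknown or untested is made for them only; others in the source may bear on it.

Compound 1 `COc1ccc(-n2nncc2CN2C(=O)C3(C(C#N)=C(N)Oc4c3c3nc5ccccc5nc3c3ccccc43)c3ccccc32)cc1` is measured in a functional assay on MCF7 cells (Homo sapiens) for antiproliferative activity, read by MTT assay, with a stated time of 48 h (on this read-out higher numbers stand for weaker inhibition and lower numbers for stronger inhibition), and returns only the limit > 50000 nM. Compound 2 `N#CC1=C(N)Oc2c(c3nc4ccccc4nc3c3ccccc23)C12C(=O)N(Cc1cnnn1-c1ccc([N+](=O)[O-])cc1)c1ccccc12` likewise returns only the limit > 50000 nM. Compound 3 `Cc1cccc(-n2nncc2CN2C(=O)C3(C(C#N)=C(N)Oc4c(N)cc5nc6ccccc6nc5c43)c3ccccc32)c1` also stands at the limit > 50000 nM. Among the measured compounds shown here, the one step between measured compounds, a step that the two limits leave unreadable from compound 1 to compound 2, is therefore of unreadable size. Because the limit of > 50000 nM in this assay, at which 3 of the 3 values shown sit, holds every value shown, nothing measured separates the three compounds.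

Compound 4 `COc1ccccc1-n1nncc1CN1C(=O)C2(C(C#N)=C(N)Oc3c(N)cc4nc5ccccc5nc4c32)c2ccccc21` differs from compound 3 by 2-methoxyphenyl in place of 3-methylphenyl on an aromatic nitrogen. For the measured compounds named here, no measured step concerns a change on this aromatic nitrogen, and the single measured step in this assay gives no readable size. Compound 4 is thus expected to remain near the limit, with an estimated step that the limit leaves unreadable from compound 3 to compound 4 and no direction beyond the scatter. The estimate for compound 4 is 60000 nM, from 15000 nM to 200000 nM.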

Compound 4, half-maximal inhibitory concentration: 28900 nM
Compound 4: middle estimate off by 2.1-fold (0.32 log units), on the high side, and the stated range covers the measured number.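

In this assay, compound 4 is the only compound shown with a number rather than a limit, which makes this aromatic nitrogen the only position so far where a change can be given a floor on its size. Putting 2-methoxyphenyl in place of 3-methylphenyl gives an at least 1.7-fold lower number from compound 3 to compound 4 (0.23 log units; that floor lies within the scatter), and a floor of that size does not establish a real difference. The rest of the series offers no measured reference point: the limit of > 50000 nM in this assay, at which 3 of the 4 values shown sit.

From the compounds shown here alone, whether the true gap between these two compounds exceeds the scatter remains open. Also open, going by these compounds, is how an amine or a carboxylic acid on this phenyl ring would read out.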